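Swapping the thiazole attachment point in an imidazoline aryl ether

A few compounds are considered here, and "the series" means these few. Any claim that something is new, unique, unknown or untested is made for them only; others in the source may bear on it.

Compound 2 `c1ccc(-c2ccns2)c(OCC2=NCCN2)c1` sits at the top of the two numbers measured in a functional assay with Alpha-1A adrenergic receptor (Homo sapiens) as the target, read by calcium flux (on this read-out lower numbers stand for smaller maximal responses and higher numbers for larger maximal responses), with compound 2 giving 99% there. Going by the values given here, its only neighbour on record is compound 1 `c1cnc(-c2ccccc2OCC2=NCCN2)nc1`, for which compound 1 gives 90% in this assay; the step of a number 9 percentage points higher from compound 1 to compound 2 (within the scatter) is the only measured step, and it stays within the scatter.

Compound 3 `c1ccc(-c2nccs2)c(OCC2=NCCN2)c1` is the next step. It differs from compound 2 by 1,3-thiazol-2-yl in place of 1,2-thiazol-5-yl on an aromatic carbon, so the two share every atom and differ only in how the five-membered ring is joined to the aromatic carbon of the six-membered ring of carbon only.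

Among the compounds with values here, no measured step covers this exact change. Within the data shown here, the one step that bears on it at all, a number 9 percentage points higher from compound 1 to compound 2 (within the scatter), shows that exchanging one heteroaryl group for another at the same place left the maximal response in this assay within the scatter. On that basis compound 3 is expected to give 95% in this assay, with a range from 80% to 105%, so that the expected step of a number 4 percentage points lower from compound 2 to compound 3 (within the scatter) lies within the scatter.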

Compound 3, largest response reached (reported as maximum), in percent of the reference or control that the assay uses: 102%
Compound 3: the middle estimate sits 7 percentage points below what was measured; measured number inside the range.
By their numbers in this assay, from the lowest: compounds 1, 2 and 3 (each within the scatter of the next, the first and the last beyond it).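

In this assay, 1,3-thiazol-2-yl in place of 1,2-thiazol-5-yl gave a number 3 percentage points higher from compound 2 to compound 3 (within the scatter) and so showed that, at this position ortho to a group of 7 heavy atoms, a change that keeps every atom and alters only how the five-membered ring is joined leaves the maximal response within the usual spread of repeats. The comparison with pyrimidin-2-yl adds the first difference at this position that clears the scatter, since 1,3-thiazol-2-yl in its place gave a number 12 percentage points higher from compound 1 to compound 3 (beyond the scatter), a modest gap, while compound 2 stays within the scatter of both of the others. No information is at hand that would account for these numbers.

On these data alone, all three compounds carry an aromatic ring with nitrogen at this position, so the response with a simple amine, a carboxylic acid or a longer alkyl chain there remains open. Also open, as far as these compounds go, is whether the thiazole swap would behave in the same way on any core other than the shared one.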